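Imidazole methylation across two butynyl-linked cores

The source may hold more compounds than are shown below. What is called first, only, known or untested is meant among the compounds shown, and "the series" means these compounds.

Compound 1 `CC(C#CCn1ccnc1)N1CCCC1=O` in a functional assay on the whole organism for agonist activity, with Mus musculus as the target (a lower number here means that less compound is needed, a higher number that more compound is needed for the effect), gives only a limit, > 100 mg/kg. Compound 2 `Cc1cncn1CC#CC(C)N1CCCC1=O` likewise gives only a limit in this assay, > 100 mg/kg. The change from compound 1 to compound 2 is methyl in place of hydrogen on an aromatic carbon; the step that the two limits leave unreadable from compound 1 to compound 2 cannot be read because the limit of > 100 mg/kg in this assay, at which 2 of the 3 values shown sit, hides it. Compound 3 `COC(=O)N(C)CC#CCn1ccnc1` carries a different core; how it differs from the core of compound 1 is not broken down here. In this assay compound 3 gives 4.5 mg/kg. Compound 4 `COC(=O)N(C)CC#CCn1cncc1C` is not yet measured; it differs from compound 3 by methyl in place of hydrogen on an aromatic carbon, the same change seen from compound 1 to compound 2. Since that earlier step is unreadable, a small step of a 1.3-fold higher number from compound 3 to compound 4 (0.12 log units; within the scatter) is expected. Compound 4 is estimated at 6 mg/kg, between 2 mg/kg and 25 mg/kg.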

Compound 4, dose for half-maximal effect: > 100 mg/kg
Compound 4 was reported as a limit; the forecaster's own chance of this, stated with the estimate: 15%; middle value at least 16-fold (1.22 log units) from the limit.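

In this assay methyl in place of hydrogen on an aromatic carbon gives an at least 22-fold higher number from compound 3 to compound 4 (1.34 log units; beyond the scatter), a large step on the core of compound 3. Compound 4 is reported only as a limit, > 100 mg/kg, so the full size of this step is not known. The steps on the core of compound 1 cannot be read, so these compounds do not show whether the change carries from one core to the other: the limit of > 100 mg/kg in this assay, at which 3 of the 4 values shown sit.

As far as these compounds go, whether an ethyl group or a chlorine atom on the same aromatic carbon gives a number in this assay stays open. Also open, from the compounds shown here alone, is whether methyl on another carbon of this ring is tolerated on the core of compound 3.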